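A few compounds are considered here, and "the series" means these few. Any claim that something is new, unique, unknown or untested is made for them only; others in the source may bear on it.

Measured compounds:

Compound 1, `CCCCCCCCn1cc(COC2(C(F)(F)F)Oc3ccccc3C=C2C(=O)OCC)nn1`: in a functional assay on A549 cells (Homo sapiens) for inhibition, read by MTT assay, with a stated time of 24 h (a higher number here means a weaker inhibitor, a lower number a stronger inhibitor), compound 1 gives > 150000 nM, which is a limit of the assay and not a number.
Compound 2, `CCOC(=O)C1=Cc2ccccc2OC1(OCc1cn(-c2ccccc2)nn1)C(F)(F)F`: in this assay compound 2 gives > 150000 nM, again a limit of the assay.
Compound 3, `CCOC(=O)C1=Cc2ccccc2OC1(OCc1cn(CC(=O)Nc2ccccc2Br)nn1)C(F)(F)F`: in this assay compound 3 gives > 150000 nM, also a limit of the assay.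

Compound 3 thus stands where every value shown stands, at the limit of > 150000 nM in this assay, at which 3 of the 3 values shown sit. None of the three steps among the measured compounds can be read: a step that the two limits leave unreadable from compound 1 to compound 2, a step that the two limits leave unreadable from compound 1 to compound 3 and a step that the two limits leave unreadable from compound 2 to compound 3 are all steps whose size the two limits hide. Whether varying the substituent on the aromatic nitrogen of the triazole ring moves this assay at all is therefore unknown from these data.

Compound 4, `CCOC(=O)C1=Cc2ccccc2OC1(OCc1cn(-c2ccc(F)c(Cl)c2)nn1)C(F)(F)F`, is the next member. It differs from compound 3 by 3-chloro-4-fluorophenyl in place of ((2-bromophenyl)carbamoyl)methyl on an aromatic nitrogen. All three measured steps touch the same position, but none of them gives a readable size, so no direction can be taken from them. With every value shown sitting at the limit, the expectation for compound 4 is that this assay again reports only a limit, with the estimated step that the limit leaves unreadable from compound 3 to compound 4. Compound 4 is estimated at 250000 nM, with a range from 100000 nM to 800000 nM.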

Compound 4, half-maximal inhibitory concentration: 26300 nM
Compound 4: middle estimate off by 9.5-fold (0.98 log units), on the high side, outside the stated range (below it).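

The group on the aromatic nitrogen of the five-membered aromatic ring does move this assay, and 3-chloro-4-fluorophenyl in place of ((2-bromophenyl)carbamoyl)methyl gives an at least 5.7-fold lower number from compound 3 to compound 4 (0.75 log units; beyond the scatter), while the same group in place of octyl gives an at least 5.7-fold lower number from compound 1 to compound 4 (0.75 log units; beyond the scatter). The closest comparison is with plain phenyl, where the two halogens on the same ring give an at least 5.7-fold lower number from compound 2 to compound 4 (0.75 log units; beyond the scatter), so an aromatic ring on this nitrogen is not enough by itself to bring a value off the limit. All three sizes are minimums, and compound 4 is the only member with a readable number: the limit of > 150000 nM in this assay, at which 3 of the 4 values shown sit.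

Going by these compounds, whether chlorine alone or fluorine alone on the phenyl ring is enough remains open. So does whether a phenyl ring carrying an amine or a carboxylic acid would also give a readable value.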